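Adding a second methyl to the amine nitrogen

A few compounds are considered here, and "the series" means these few. Any claim that something is new, unique, unknown or untested is made for them only; others in the source may bear on it.

In a functional assay on HCT-8 cells (Homo sapiens) for antiproliferative activity, read by MTT assay, with a stated time of 48 h (on this read-out lower numbers stand for stronger inhibition and higher numbers for weaker inhibition), compound 1 `C=C(c1ccc2c(c1)C=CC(C)(C)O2)c1ccc(OC)cc1NC(=O)CN` gives 220 nM and compound 2 `C=C(c1ccc2c(c1)C=CC(C)(C)O2)c1ccc(OC)cc1NC(=O)CNC` gives 590 nM as the higher of the two numbers. Compound 3 `C=C(c1ccc2c(c1)C=CC(C)(C)O2)c1ccc(OC)cc1NC(=O)CN(C)C` follows from compound 2 by methyl in place of hydrogen on an amine nitrogen in a change of methyl in place of hydrogen on an amine nitrogen, methylamino to dimethylamino. Going by the values given here, the one measured step bearing on this is the same kind of replacement, a 2.7-fold higher number from compound 1 to compound 2 (0.43 log units; beyond the scatter) and so modest but beyond the scatter. A further move to a higher number in this assay of similar size is therefore expected, though a single step gives thin support. The expected change is a 2.2-fold higher number from compound 2 to compound 3 (0.34 log units; beyond the scatter) in this estimate. Compound 3 is estimated at 1300 nM with a likely range from 500 nM to 3500 nM on this read-out.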

Compound 3, half-maximal inhibitory concentration: 690 nM
The estimate for compound 3 lay 1.9-fold (0.28 log units) above the measured number; measured number inside the range.
By their numbers in this assay, from the lowest: compound 1; then compounds 2 and 3 (each within the scatter of the next).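

In this assay the second methyl on the amine nitrogen gives a 1.2-fold higher number from compound 2 to compound 3 (0.07 log units; within the scatter) and so does not repeat the step beyond the scatter seen with the first methyl. Dimethylamino in place of amino gives a 3.1-fold higher number from compound 1 to compound 3 (0.50 log units; beyond the scatter) as a modest step, so both methylated compounds stand apart from compound 1 while compounds 2 and 3 cannot be told apart. Still open, from the compounds shown here alone, is how an ethyl group on this nitrogen, or a carboxylic acid in place of the amine, would read here. No evidence on hand accounts for this flat second step.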